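Trading chloro for fluoro in a growth-inhibition series

The source may hold more compounds than are shown below. What is called first, only, known or untested is meant among the compounds shown, and "the series" means these compounds.

Compounds sharing one core differ here only in a single group, and each has been read in an ADME assay on HEK-293T cells (Homo sapiens) for inhibition, read by CCK-8 assay, with a stated time of 48 h, tested at 20 uM; a higher number here means more inhibition of growth at the concentration tested, a lower number less inhibition of growth. Compound 1 (`COc1ccc(Cc2nnc(NC(=O)/C(C#N)=C/c3ccccc3OS(=O)(=O)c3ccc(OC)cc3)s2)cc1`), which carries methoxy, gives 30%. Compound 2 (`COc1ccc(Cc2nnc(NC(=O)/C(C#N)=C/c3ccccc3OS(=O)(=O)c3ccc([N+](=O)[O-])cc3)s2)cc1`), which carries nitro, gives 17%. Compound 3 (`COc1ccc(Cc2nnc(NC(=O)/C(C#N)=C/c3ccccc3OS(=O)(=O)c3ccc(Cl)cc3)s2)cc1`), which carries chloro, gives 34%. That places compound 3 level with compound 1 within the usual scatter, and clearly above compound 2.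

The next structure is compound 4 (`COc1ccc(Cc2nnc(NC(=O)/C(C#N)=C/c3ccccc3OS(=O)(=O)c3ccc(F)cc3)s2)cc1`), and the change is small: fluoro in place of chloro on an aromatic carbon. Put simply, this is fluoro in place of chloro on an aromatic carbon, para to a large group.

Three measured steps at this same place bear on it. Chloro in place of methoxy gave a number 4 percentage points higher from compound 1 to compound 3 (within the scatter). The two modest steps both involve the nitro group of compound 2: a number 13 percentage points lower from compound 1 to compound 2 (beyond the scatter) and a number 17 percentage points higher from compound 2 to compound 3 (beyond the scatter). Going by the values given here, no fluoro compound has been measured yet, so the closest guide is the small methoxy-to-chloro step, and no move beyond the scatter is expected. The expected step is a number 3 percentage points lower from compound 3 to compound 4 (within the scatter). For compound 4 the estimated value is 31%, with a likely range of 20% to 42%.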

Compound 4, percent growth inhibition at one concentration: 6%
Compound 4: the middle estimate sits 25 percentage points above what was measured; the whole stated range lies above it.
By their numbers in this assay, from the lowest: compound 4; then compound 2; then compounds 1 and 3 (each within the scatter of the next).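

This position turns out to be more sensitive than the methoxy and chloro pair suggested: swapping one halogen atom for another, with no change in the counted hydrogen-bond donors or acceptors, gives a number 28 percentage points lower from compound 3 to compound 4 (beyond the scatter) in this assay and is the largest step yet seen at this place. Fluoro also separates from both other groups, with a number 11 percentage points lower from compound 2 to compound 4 (beyond the scatter) and a number 24 percentage points lower from compound 1 to compound 4 (beyond the scatter) on the same read-out, which makes compound 4 the lowest of the four and shows that chloro and fluoro cannot be treated as interchangeable here. No available evidence explains why this single-atom change has such an effect.

The compounds shown leave open whether the low reading is particular to fluoro or would also appear with another small group at this place, such as bromo, methyl or plain hydrogen. They also leave open how an amine or a carboxylic acid on the same aromatic carbon would read, and with only one tested concentration, how the four compounds would compare at other concentrations.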